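Fluoro on the aryl ring: expected binding of compound 4

A few compounds are considered here, and "the series" means these few. Any claim that something is new, unique, unknown or untested is made for them only; others in the source may bear on it.

Measured so far:
compound 1 `Cc1nc2sc(-c3ccccc3)nc2c(=O)[nH]1` 11%
compound 2 `Cc1nc2sc(-c3ccc(C(F)(F)F)cc3)nc2c(=O)[nH]1` 1%
compound 3 `Cc1nc2sc(-c3ccc(O)cc3)nc2c(=O)[nH]1` 1%

In an assay on CHO cells for displacement of a labelled ligand from adenosine receptor A1 (Homo sapiens), read by scintillation counting, with a stated time of 120 min, tested at 1 uM (a lower number here means less inhibition, a higher number more inhibition at the concentration tested (going by the name of the read-out)), compound 1 has the highest of the three numbers, though its lead over compound 2 a number 10 percentage points lower from compound 1 to compound 2 (within the scatter) and over compound 3 a number 10 percentage points lower from compound 1 to compound 3 (within the scatter) lies within the scatter, as does the step of no change at the digits printed from compound 2 to compound 3 (within the scatter). Compound 4 `Cc1nc2sc(-c3cccc(F)c3)nc2c(=O)[nH]1` differs from compound 1 by fluoro in place of hydrogen on an aromatic carbon, placed on an aromatic carbon of a six-membered aromatic ring of carbon only, meta to a large group. The two steps that bear on it, putting a group on that ring, both gave no change beyond the scatter. For compound 4 no step beyond the scatter is therefore expected, with an estimated step of a number 5 percentage points lower from compound 1 to compound 4 (within the scatter). Compound 4 is estimated at 6%, within -6% to 18%.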

Compound 4, a percentage reported as inhibition, at one concentration (the size of the read-out at that concentration, not a potency): 1%
Estimate against measurement, compound 4: 5 percentage points above, within the range that was stated.
By their numbers in this assay, from the lowest: compounds 2, 3, 4 and 1 (each within the scatter of the next).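

In this assay, within the data shown here, fluoro meta to a large group gives a number 10 percentage points lower from compound 1 to compound 4 (within the scatter), so fluoro at this place on the ring, which no earlier compound in the set occupies, adds no step beyond the scatter. With trifluoromethyl and hydroxy, all three changes on this ring now lie within the scatter of compound 1. No measurement at hand explains these numbers.

Still open, from the compounds shown here alone, is whether an amine or a carboxylic acid on this ring, or a longer chain in place of the methyl on the shared core, would give a step beyond the scatter.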